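The source may hold more compounds than are shown below. What is called first, only, known or untested is meant among the compounds shown, and "the series" means these compounds.

Compound 1 `O=C1C=C(Nc2cccc(F)c2)C(=O)c2c1nc1n2[C@H]2OC[C@@H](O)[C@H]2OC1`: 2180 nM
Compound 2 `CCCN(CCC)C1=CC(=O)c2nc3n(c2C1=O)[C@H]1OC[C@@H](O)[C@H]1OC3`: > 16000 nM

Both were read in a functional assay on MGC-803 cells (Homo sapiens) for inhibition, read by sulforhodamine B assay; a higher number here means a weaker inhibitor, a lower number a stronger inhibitor. For compound 2 the entry > 16000 nM is a limit of the assay and not a number. Compound 3 `O=C1C=C(Nc2ccc(I)cc2)C(=O)c2c1nc1n2[C@H]2OC[C@@H](O)[C@H]2OC1` carries (4-iodophenyl)amino in place of dipropylamino on the double-bonded ring carbon: (4-iodophenyl)amino in place of dipropylamino on a double-bonded ring carbon. For the measured compounds named here, one measured step bears on this, an at least 7.3-fold higher number from compound 1 to compound 2 (0.86 log units; beyond the scatter), which lies beyond the scatter and runs the opposite way, from an aromatic amine to dipropylamino. A return to a lower number in this assay is therefore expected, of at least similar size, with an at least 7.2-fold lower number from compound 2 to compound 3 (0.86 log units; beyond the scatter) as the estimated step. For compound 3 the expected value is 2200 nM, with an estimated range of 650 nM to 7500 nM.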

Compound 3, half-maximal inhibitory concentration: 1400 nM
Compound 3: middle estimate off by 1.6-fold (0.20 log units), on the high side; the measured number falls inside the stated range.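

In this assay, a second aromatic amine on the double-bonded ring carbon gives a clear separation from dipropylamino, an at least 11-fold lower number from compound 2 to compound 3 (1.05 log units; beyond the scatter), so the gap no longer rests on compound 1 alone. Exchanging 3-fluorophenyl for 4-iodophenyl on the amine nitrogen stays within the scatter, a 1.6-fold lower number from compound 1 to compound 3 (0.19 log units; within the scatter). The value of compound 2 is a limit of the assay and not a number, so the first step has no measured size: the limit of > 16000 nM in this assay, at which 1 of the 3 values shown sits.

Compound 1 and compound 3 both carry an aromatic ring and the amine hydrogen, whereas compound 2 has neither, so the two features remain unseparated. Cyclohexylamino and methyl(phenyl)amino at this carbon would tell them apart.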